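Cytotoxicity notes on three measured analogues and one pending

The source may report more compounds than this note shows. Statements on the series, on what has been measured and on what is new or still open speak of the compounds shown alone.

Values in an ADME assay on MT4 cells (Homo sapiens) for cytotoxicity, read by MTT assay, with a stated time of 4 days; on this read-out higher numbers stand for lower toxicity in this test and lower numbers for higher toxicity in this test:
compound 1 `Cc1cc(-c2ccccc2C(F)(F)F)cc(C)c1Nc1ccnc(Nc2ccc(C#N)cc2)n1` gives 4210 nM
compound 2 `Cc1cccc(-c2cc(C)c(Nc3ccnc(Nc4ccc(C#N)cc4)n3)c(C)c2)c1` gives 3670 nM
compound 3 `Cc1ccc(-c2cc(C)c(Nc3ccnc(Nc4ccc(C#N)cc4)n3)c(C)c2)cc1` gives 5570 nM
compound 4 `Cc1cc(-c2ccc(F)cc2)cc(C)c1Nc1ccnc(Nc2ccc(C#N)cc2)n1` awaits measurement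

Compound 2 stands at the low end of the three numbers in this assay, but its nearest neighbour is compound 1 at a 1.1-fold lower number from compound 1 to compound 2 (0.06 log units; within the scatter) and its furthest is compound 3 at a 1.5-fold higher number from compound 2 to compound 3 (0.18 log units; within the scatter); both steps lie within the scatter, as does a 1.3-fold higher number from compound 1 to compound 3 (0.12 log units; within the scatter), so the three compounds cannot be separated on this read-out.

The change to compound 4 is 4-fluorophenyl in place of 3-methylphenyl on an aromatic carbon. Within the data shown here, no measured pair introduces a fluorine, so the bearing of the existing data is indirect: the three exchanges at the same aromatic carbon, a 1.1-fold lower number from compound 1 to compound 2 (0.06 log units; within the scatter), a 1.3-fold higher number from compound 1 to compound 3 (0.12 log units; within the scatter) and a 1.5-fold higher number from compound 2 to compound 3 (0.18 log units; within the scatter), all stayed within the scatter, and no step beyond the scatter is expected here either. Compound 4 is therefore estimated at 4200 nM, with a range of 2000 nM to 9000 nM. This estimate corresponds to an expected step of a 1.1-fold higher number from compound 2 to compound 4 (0.06 log units; within the scatter).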

Compound 4, half-maximal cytotoxic concentration: 4170 nM
Estimate against measurement, compound 4: 1.0-fold (0.00 log units) above; the measured number falls inside the stated range.
By their numbers in this assay, from the lowest: compounds 2, 4, 1 and 3 (each within the scatter of the next).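

In this assay, a fluorine on the aryl group at this aromatic carbon gives no separation from any earlier compound: a 1.1-fold higher number from compound 2 to compound 4 (0.06 log units; within the scatter), a 1.3-fold lower number from compound 3 to compound 4 (0.13 log units; within the scatter) and a 1.0-fold lower number from compound 1 to compound 4 (0.00 log units; within the scatter). The second of these steps is the closest exchange in the set, fluoro in place of methyl on an aromatic carbon, and it extends the flat picture from carbon-only substituents to a halogen on the same aryl group. With all four compounds within the scatter of one another, 4-fluorophenyl, 3-methylphenyl, 4-methylphenyl and 2-(trifluoromethyl)phenyl cannot be told apart at this position, and no supporting data explain this result.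

Going by these compounds, all four compounds carry a substituted phenyl group here, so it remains open whether an amine or a carboxylic acid on that ring would move the number beyond the scatter. On these data alone, whether replacing the phenyl group with a longer chain would do so also remains open.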